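Methyl in Place of Cyclohexyl on the Ring Nitrogen

A few compounds are considered here, and "the series" means these few. Any claim that something is new, unique, unknown or untested is made for them only; others in the source may bear on it.

Measured in a functional assay on HeLa cells (Homo sapiens) for antiproliferative activity, read by CCK-8 assay, with a stated time of 72 h, tested at 8 uM; on this read-out lower numbers stand for a weaker effect and higher numbers for a stronger effect at the one concentration tested:
- compound 1 `Nc1ccccc1NC(=O)c1ccc(CSC(=S)N2CCN(C3CCCCC3)CC2)cc1` gives 76.1%
- compound 2 `CN(Cc1ccncc1)C(=S)SCc1ccc(C(=O)Nc2ccccc2N)cc1` gives 72.7%
- compound 3 `Nc1ccccc1NC(=O)c1ccc(CSC(=S)N2CCc3cc(Cl)ccc32)cc1` gives 65.1%

Compound 1 stands highest of the three numbers; compound 2 lies within the scatter of it, and only compound 3 lies beyond the scatter below it. Compound 4 `CN1CCN(C(=S)SCc2ccc(C(=O)Nc3ccccc3N)cc2)CC1` differs from compound 1 in one place: methyl in place of cyclohexyl on an amine nitrogen in a ring. Going by the values given here, the one measured step, a number 7.6 percentage points lower from compound 2 to compound 3 (within the scatter), replaces the whole amine on the thiocarbonyl carbon and lay within the scatter, so it bears only loosely on a change at the ring nitrogen. A small downward step is therefore expected, a number 10.1 percentage points lower from compound 1 to compound 4 (beyond the scatter), without certainty that it exceeds the scatter. Compound 4 is estimated at 66%, with a range from 50% to 80%.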

Compound 4, a percentage reported as inhibition, at one concentration (the size of the read-out at that concentration, not a potency): 75.7%
Beside the measured number, compound 4's estimate is 9.7 percentage points below it; low and high end bracket the measured number.
By their numbers in this assay, from the lowest: compounds 3, 2, 4 and 1 (each within the scatter of the next, the first and the last beyond it).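

In this assay, methyl in place of cyclohexyl on the ring nitrogen gives a number 0.4 percentage points lower from compound 1 to compound 4 (within the scatter), so the cyclohexyl ring is not needed to keep this effect at the one concentration tested. With 4-methylpiperazin-1-yl on the thiocarbonyl carbon, the comparisons are a number 3 percentage points higher from compound 2 to compound 4 (within the scatter) and a number 10.6 percentage points higher from compound 3 to compound 4 (beyond the scatter), and only the second lies beyond the scatter. No measured evidence here explains these numbers. As far as these compounds go, it remains open whether a carboxylic acid or a longer chain ending in an amine on this ring nitrogen would keep the effect. A single concentration also leaves potency unknown.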